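The source may report more compounds than this note shows. Statements on the series, on what has been measured and on what is new or still open speak of the compounds shown alone.

Compound 1 `C#CCN(C)Cc1cn(-c2cc(NC(=S)NCC)ncn2)cn1` gives 20.2% in an assay on isolated protein for inhibition of Amine oxidase [flavin-containing] A (Homo sapiens), read by fluorescence and Amplex Red, with a stated time of 15 min, tested at 50 uM (a lower number here means less inhibition, a higher number more inhibition at the concentration tested (going by the name of the read-out)), the highest of the three numbers measured. Compound 2 `C#CCN(Cc1cn(-c2cc(NC(=S)NCC)ncn2)cn1)C(C)=O` gives 4.83%, and the step of a number 15.4 percentage points lower from compound 1 to compound 2 (beyond the scatter) is acetyl in place of methyl on an amine nitrogen. Compound 3 `C#CCN(Cc1ccccc1)Cc1cn(-c2cc(NC(=S)NCC)ncn2)cn1` gives 17.8%; the step of a number 2.4 percentage points lower from compound 1 to compound 3 (within the scatter) places phenyl in place of hydrogen on a saturated chain carbon bound to an amine nitrogen. Between them, a number 13 percentage points higher from compound 2 to compound 3 (beyond the scatter) puts benzyl in place of acetyl on an amine nitrogen.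

Compound 4 `C#CCN(CC#N)Cc1cn(-c2cc(NC(=S)NCC)ncn2)cn1` differs from compound 1 by cyano in place of hydrogen on a saturated chain carbon bound to an amine nitrogen. The change sits at the same place as the step to compound 3, which stayed within the scatter, so the expected step of a number 4.2 percentage points lower from compound 1 to compound 4 (within the scatter) is small and in no settled direction. Compound 4 is estimated at 16%, within 5% to 28%.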

Compound 4, a percentage reported as inhibition, at one concentration (the size of the read-out at that concentration, not a potency): 2.01%
Beside the measured number, compound 4's estimate is 14 percentage points above it, and the stated range ends above it.
By their numbers in this assay, from the lowest: compounds 4 and 2 (each within the scatter of the next); then compounds 3 and 1 (each within the scatter of the next).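

At the saturated chain carbon bound to an amine nitrogen, the outcome in this assay depends on the group: phenyl stayed within the scatter, but cyano gives a number 18.2 percentage points lower from compound 1 to compound 4 (beyond the scatter), and the two groups compared directly give a number 15.8 percentage points lower from compound 3 to compound 4 (beyond the scatter). Cyanomethyl in place of acetyl on the amine nitrogen gives a number 2.8 percentage points lower from compound 2 to compound 4 (within the scatter), so these two groups are not separated. No measurement shown here accounts for the drop with cyano.

Open, from the compounds shown here alone, is whether a carboxylic acid, a primary amine or a longer alkyl chain on that carbon would track phenyl or cyano.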